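The source may hold more compounds than are shown below. What is called first, only, known or untested is meant among the compounds shown, and "the series" means these compounds.

Compound 1 `COc1ccccc1-n1c(Nc2nc(-c3ccccc3)cs2)n[nH]c1=S` gives 100 mg/kg in a functional assay on the whole organism (strain Swiss albino) for inhibition, with Mus musculus as the target, with a stated time of 0.5 h; on this read-out lower numbers stand for an effect already at smaller amounts and higher numbers for an effect only at larger amounts of compound. Compound 2 `COc1ccc(-n2c(Nc3nc(-c4ccccc4)cs3)n[nH]c2=S)cc1` gives 100 mg/kg in this assay, and the step of no change at the digits printed from compound 1 to compound 2 (within the scatter) leaves compound 1 level with compound 2 at the digits shown. Compound 3 `COc1ccccc1-n1c(Nc2nc(-c3ccc(Br)cc3)cs2)n[nH]c1=S` differs from compound 1 by bromo in place of hydrogen on an aromatic carbon. For the measured compounds named here, no measured step touches this aromatic carbon; the sole step, no change at the digits printed from compound 1 to compound 2 (within the scatter), concerns the group on the aromatic nitrogen and lay within the scatter, so it bears on the present change only loosely. The step of no change at the digits printed from compound 1 to compound 3 (within the scatter) is expected to stay within the scatter. For compound 3 in this assay the estimate is 100 mg/kg, ranging from 50 mg/kg to 200 mg/kg.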

Compound 3, minimum effective dose: 300 mg/kg
For compound 3 the middle estimate is 3.0-fold (0.48 log units) below the measured one; the whole stated range lies below it.
By their numbers in this assay, from the lowest: compounds 1 and 2 (each within the scatter of the next); then compound 3.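

For the compounds shown here, the step of a 3.0-fold higher number from compound 1 to compound 3 (0.48 log units; beyond the scatter) in this assay is the first to lie beyond the scatter. It shows that this aromatic carbon responds to substitution: with bromo in place of hydrogen, the effect appears only at a larger amount of compound. Nothing at hand explains this shift.

On these data alone, whether fluoro, chloro, methoxy or an amine at this carbon would give a similar step remains open. So does whether phenyl to 4-bromophenyl would give the same step in compound 2.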